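The source may report more compounds than this note shows. Statements on the series, on what has been measured and on what is new or still open speak of the compounds shown alone.

In an ADME assay on microsomes from liver (Rattus norvegicus, strain Crj;CD(SD)) for metabolic stability, read by LC-MS, using NADPH, with a stated time of 30 min, tested at 0.1 uM (a lower number here means that less of the compound is left, a higher number that more of the compound is left), two compounds have been measured so far. Compound 1 `Cc1cc(C#N)cnc1C(=O)Nc1ccc(F)c([C@]2(C)C=C(CF)OC(N)=N2)c1` gives 34%, and compound 2 `C[C@@]1(c2cc(NC(=O)c3ccc(C#N)cn3)ccc2F)C=C(CF)OC(N)=N1` gives 55%, the higher of the two numbers. The next structure, compound 3 `COc1cnc(C(=O)Nc2ccc(F)c([C@]3(C)C=C(CF)OC(N)=N3)c2)cn1`, keeps the shared core and changes the group on the carbonyl carbon: 5-methoxypyrazin-2-yl in place of 5-cyanopyridin-2-yl on a carbonyl carbon. Among the compounds with values here, only one measured step bears on this, and only indirectly: a number 21 percentage points higher from compound 1 to compound 2 (beyond the scatter), which came with hydrogen in place of methyl on an aromatic carbon. Within the data shown here, that step shows that this read-out can respond to a small structural change, but no measured compound carries 5-methoxypyrazin-2-yl, so the data give no direct guide to size or direction. No step beyond the scatter is therefore expected, only a slight lean downward from compound 2 at 55%. The expected change is a number 7 percentage points lower from compound 2 to compound 3 (within the scatter). In this assay, the estimated value for compound 3 is 48%, with an expected range from 28% to 66%.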

Compound 3, percent of the compound remaining: 13%
For compound 3 the middle estimate is 35 percentage points above the measured one, outside the stated range (below it).
By their numbers in this assay, from the lowest: compound 3; then compound 1; then compound 2.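

In this assay, the group on the carbonyl carbon turns out to be a far more sensitive place than the earlier pair could show: 5-methoxypyrazin-2-yl in place of 5-cyanopyridin-2-yl gives a number 42 percentage points lower from compound 2 to compound 3 (beyond the scatter). The same group in place of 5-cyano-3-methylpyridin-2-yl gives a number 21 percentage points lower from compound 1 to compound 3 (beyond the scatter), so the drop holds against both nitrile-bearing compounds, whether or not the methyl is present. The data at hand offer no measurement that accounts for this drop.

This change alters the ring and its substituent at once, so the compounds shown cannot say whether the second ring nitrogen, the methoxy group or the loss of the nitrile matters most. Going by these compounds, how a 5-methoxypyridin-2-yl or a 5-cyanopyrazin-2-yl group would behave in this assay remains open, and either would help to separate those parts.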